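Replacing the isopropylamino pyridine of compound 2

The compounds below may be only part of what the source reports. "The series", "measured", "known", "first", "only" and "open" are said of these compounds alone.

For the measured compounds named here, in a physicochemical assay for lipophilicity, read by spectrophotometry, measured as octanol-water partition, at pH 7.4 (a higher number here means a more lipophilic compound, a lower number a more polar compound), compound 2 (`CCOc1cc(CN2CCC(NC(=O)c3ccc(NC(C)C)nc3)CC2)cc(OCC)c1F`) gives 3.39 as the only number so far. Compound 1 (`CCOc1cc(CN2CCC(NC(=O)c3cncc(C)c3)CC2)cc(OCC)c1-c1ccc(OC(F)(F)F)cc1`) reads > 4 as a limit of the assay and not a number. Compound 3 (`CCOc1cc(CN2CCC(NC(=O)c3cncc(C)c3)CC2)cc(OCC)c1F`) differs from compound 2 by one change (5-methylpyridin-3-yl in place of 6-(isopropylamino)pyridin-3-yl on a carbonyl carbon) with 5-methylpyridin-3-yl in place of 6-(isopropylamino)pyridin-3-yl on a carbonyl carbon. Going by the values given here, no measured step covers this change, so the expectation rests only on compound 2 (3.39) and the smaller entering group. A moderate fall in this assay is expected (a number 0.49 log units lower from compound 2 to compound 3 (beyond the scatter)). Compound 3 is estimated at 2.9 (range 2.4 to 3.4).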

Compound 3, distribution coefficient: 2.9
Compound 3: the middle estimate sits on the measured number at the digits printed; low and high end bracket the measured number.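

In this assay, the group on the carbonyl carbon now has a measured effect: 5-methylpyridin-3-yl in place of 6-(isopropylamino)pyridin-3-yl gives a number 0.49 log units lower from compound 2 to compound 3 (beyond the scatter). The aromatic carbon also gains a step, with fluoro in place of 4-(trifluoromethoxy)phenyl giving a number at least 1.10 log units lower from compound 1 to compound 3 (beyond the scatter). Compound 1 reads > 4, a limit of the assay and not a number, so this step is only a bound: the limit of > 4 in this assay, at which 1 of the 3 values shown sits.

Going by these compounds, it remains open how a carboxylic acid or a longer chain on the pyridine would read. On these data alone, a plain phenyl or chloro on the aromatic carbon is equally open.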